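The source may hold more compounds than are shown below. What is called first, only, known or untested is meant among the compounds shown, and "the series" means these compounds.

Measured so far in a functional assay on SW-620 cells (Homo sapiens) for antiproliferative activity, read by MTT assay, with a stated time of 72 h; a higher number here means a weaker inhibitor, a lower number a stronger inhibitor:
Compound 1 `O=C1O[C@H]([C@@H](O)Cn2cc(-c3cccc(O)c3)nn2)C(OCc2ccccc2)=C1OCc1ccccc1` gives > 100000 nM, which is a limit of the assay and not a number.
Compound 2 `CCCCCc1ccc(-c2cn(C[C@H](O)[C@H]3OC(=O)C(OCc4ccccc4)=C3OCc3ccccc3)nn2)cc1` gives 12200 nM.
Compound 3 `O=C1O[C@H]([C@@H](O)Cn2cc(CNS(=O)(=O)c3ccc(F)cc3)nn2)C(OCc2ccccc2)=C1OCc1ccccc1` gives 41100 nM.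

Compound 3 stands highest of the two numbers in this assay; its nearest neighbour is compound 2, with the step of a 3.4-fold higher number from compound 2 to compound 3 (0.53 log units; beyond the scatter). Toward compound 1 only the limit of > 100000 nM in this assay, at which 1 of the 3 values shown sits, is known, so the step of an at least 2.4-fold lower number from compound 1 to compound 3 (0.38 log units; beyond the scatter) can be stated only as a bound.

The next compound, compound 4 `Cc1ccc(-c2cn(C[C@H](O)[C@H]3OC(=O)C(OCc4ccccc4)=C3OCc3ccccc3)nn2)cc1`, differs from compound 3 in one place: 4-methylphenyl in place of (((4-fluorophenyl)sulfonyl)amino)methyl on an aromatic carbon.

Among the compounds with values here, two measured steps bear on this change. The closest is a 3.4-fold higher number from compound 2 to compound 3 (0.53 log units; beyond the scatter). Compound 4 again carries a substituted phenyl group on that aromatic carbon, here 4-methylphenyl rather than 4-pentylphenyl. The step of an at least 8.1-fold lower number from compound 1 to compound 2 (0.91 log units; beyond the scatter) shows that 3-hydroxyphenyl leaves the value at the limit while 4-pentylphenyl gives a number; 4-methylphenyl is neither of these. A lower number than compound 3 is therefore expected in this assay, of modest size, broadly reversing the step from compound 2 to compound 3 but not necessarily all of it. Compound 4 is estimated at 22000 nM, with a range from 7000 nM to 80000 nM, corresponding to an expected step of a 1.9-fold lower number from compound 3 to compound 4 (0.27 log units; within the scatter).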

Compound 4, half-maximal inhibitory concentration: > 100000 nM
Compound 4: no number, only a limit (the forecaster's own chance of this, stated with the estimate: 15%); middle value at least 4.5-fold (0.65 log units) from the limit.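

In this assay, a substituted phenyl group on this aromatic carbon does not by itself give a readable number: the shortening of 4-pentylphenyl to 4-methylphenyl is an at least 8.1-fold higher number from compound 2 to compound 4 (0.91 log units; beyond the scatter), so among the phenyl-bearing compounds shown only compound 2, with its pentyl chain, stays clear of the limit. The step of an at least 2.4-fold higher number from compound 3 to compound 4 (0.38 log units; beyond the scatter) shows that the (((4-fluorophenyl)sulfonyl)amino)methyl group keeps a number where 4-methylphenyl does not, so compound 3 goes against any reading that a long alkyl chain is required at this position. Compounds 1 and 4 both stand at a limit of the assay, and the step between them cannot be read: the limit of > 100000 nM in this assay, at which 2 of the 4 values shown sit.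

Where between methyl and pentyl a readable number first appears remains open, since a propyl or butyl chain on the phenyl group would be needed to place it, and a longer chain such as octyl would show whether the number keeps falling. Also open, as far as these compounds go, is whether an amine or a carboxylic acid at the end of that chain would keep the number seen for compound 2.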